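Hydroxystilbene-quinoline series: lipophilicity notes

A few compounds are considered here, and "the series" means these few. Any claim that something is new, unique, unknown or untested is made for them only; others in the source may bear on it.

Measured compounds:
- compound 1, `CCOc1ccc(/C=C/c2ccc3cccc(O)c3n2)cc1`: 4.55
- compound 2, `Oc1ccccc1/C=C/c1ccc2c(Cl)cc(Cl)c(O)c2n1`: 5.07
- compound 3, `Oc1ccc(/C=C/c2ccc3c(Cl)cc(Cl)c(O)c3n2)c(O)c1`: 4.68

All three were read in a physicochemical assay for lipophilicity, read by HPLC; on this read-out lower numbers stand for lower lipophilicity and higher numbers for higher lipophilicity. Compound 1 gives the lowest number of the three; its gap to compound 3 lies within the scatter, while compound 2 stands beyond the scatter above it. Among the measured compounds shown here, the one single-point step in the set is a number 0.39 log units higher from compound 3 to compound 2 (beyond the scatter), the change being (hydrogen in place of hydroxy on an aromatic carbon). The difference between the core of compound 1 and that of compound 3 is not broken down here.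

Compound 4, `CCOc1ccc(/C=C/c2ccc3ccccc3n2)cc1`, is not yet measured in this assay. It differs from compound 1 by hydrogen in place of hydroxy on an aromatic carbon. This is the same kind of change as that from compound 3 to compound 2, not the same: in compound 1 the hydroxy sits on a ring that is part of a fused or bridged system of two rings, ortho to a fused ring and meta to a fused ring, whereas in compound 3 it sits meta to a hydroxy group and para to a large group. Resting on the step from compound 3 to compound 2, a step of about the same size, a number 0.40 log units higher from compound 1 to compound 4 (beyond the scatter), is expected for compound 4. Compound 4 is therefore estimated at 4.95, with a range from 4.6 to 5.3.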

Compound 4, partition coefficient: 4.61
The estimate for compound 4 lay 0.34 log units above the measured number; the measured number falls inside the stated range.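

In this assay, hydrogen in place of hydroxy on an aromatic carbon gives a step within the scatter on the core of compound 1 (a number 0.06 log units higher from compound 1 to compound 4 (within the scatter)) but a step beyond the scatter on the core of compound 3 (a number 0.39 log units higher from compound 3 to compound 2 (beyond the scatter)), so the size of the step seen on one core did not carry over to the other. This shows only that the same kind of change need not give a step of the same size in this series; with one pair on each core, it does not show which step is more typical or what the change would give on any further core. Nothing available here explains the contrast between the two steps.

Still open, going by these compounds, is how an amine or a carboxylic acid on that same aromatic carbon of the core of compound 1 would read in this assay. Also open, on these data alone, is whether a longer chain in place of the ethoxy group would leave the hydroxy-to-hydrogen step on this core as small as it is here.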